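This account rests on a few compounds, and the source may have more. Where it says the series, first, only, none or still open, it means among the compounds named here.

In a functional assay on KB cells (Homo sapiens) for inhibition (on this read-out lower numbers stand for stronger inhibition and higher numbers for weaker inhibition), compound 3 `COCCOCn1c(N)c(C#N)c2c(N)ncnc21` gives 210000 nM and compound 1 `CCOCn1c(N)c(C#N)c2c(N)ncnc21` gives 138000 nM, two numbers within the scatter of each other. Compound 2 `Cc1cccc(Cn2c(N)c(C#N)c3c(N)ncnc32)c1` reads > 100000 nM, which is a limit of the assay and not a number. Compound 4 `Cc1ccc(Cn2c(N)c(C#N)c3c(N)ncnc32)cc1` carries 4-methylphenyl in place of 2-methoxyethoxy on a saturated chain carbon bound to an aromatic nitrogen. The closest measured change, with 3-methylphenyl as the group, is a step that the limit leaves unreadable from compound 2 to compound 3, so it gives no size. Among the measured compounds shown here, the only readable step is a 1.5-fold higher number from compound 1 to compound 3 (0.18 log units; within the scatter), and it is small. The step expected is therefore a 1.4-fold lower number from compound 3 to compound 4 (0.15 log units; within the scatter), nothing beyond the scatter. For compound 4 the estimate is 150000 nM, with an expected range of 70000 nM to 350000 nM.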

Compound 4, half-maximal inhibitory concentration: > 100000 nM
Compound 4 gave a limit, no number; the forecaster's own chance of this, stated with the estimate: 60%; the middle value does not contradict the limit.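

Compound 4 reads as a limit of the assay, not a number, so none of its steps from compound 1, compound 2 or compound 3 can be read: the limit of > 100000 nM in this assay, at which 2 of the 4 values shown sit.

The compounds shown leave open whether 4-methylphenyl differs from 3-methylphenyl, ethoxy or 2-methoxyethoxy on this read-out.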